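Trimming the Amine Side Chain of Compound 2

This account rests on a few compounds, and the source may have more. Where it says the series, first, only, none or still open, it means among the compounds named here.

Of the compounds shown here, two sharing one core have been measured in an assay for inhibition of Amine oxidase [flavin-containing] B (Rattus norvegicus); a lower number here means a stronger inhibitor, a higher number a weaker inhibitor. Compound 1 `C[C@H](Nc1cc(=O)oc2cc(OCc3cccc(Cl)c3)ccc12)C(N)=O` carries a (1-carbamoylethyl)amino group on an aromatic carbon and gives 210 nM. Compound 2 `CN(Cc1ccccc1)Cc1cc(=O)oc2cc(OCc3cccc(Cl)c3)ccc12` carries a (benzyl(methyl)amino)methyl group there and gives 8000 nM, the higher of the two numbers. The step of a 38-fold higher number from compound 1 to compound 2 (1.58 log units; beyond the scatter) lies beyond the scatter, so of this pair the second is the weaker inhibitor. Compound 3 `NCc1cc(=O)oc2cc(OCc3cccc(Cl)c3)ccc12` has not been measured; it differs from compound 2 by amino in place of benzyl(methyl)amino on a saturated chain carbon bound to an aromatic carbon. Within the data shown here, no measured step mirrors this change: the only step in hand, a 38-fold higher number from compound 1 to compound 2 (1.58 log units; beyond the scatter), exchanged one whole group for another and ran toward weaker inhibition, so it gives only indirect guidance. Removing the benzyl and methyl groups is expected to move the number for compound 3 modestly downward, as a 2.7-fold lower number from compound 2 to compound 3 (0.43 log units; beyond the scatter), though the direction is uncertain. Compound 3 is therefore estimated at 3000 nM, within 500 nM to 20000 nM.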

Compound 3, half-maximal inhibitory concentration: 15 nM
Beside the measured number, compound 3's estimate is 200-fold (2.30 log units) above it; the whole stated range lies above it.
By their numbers in this assay, from the lowest: compound 3; then compound 1; then compound 2.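

Swapping benzyl(methyl)amino for a plain amino group on a saturated chain carbon bound to an aromatic carbon gives a 530-fold lower number from compound 2 to compound 3 (2.73 log units; beyond the scatter) in this assay, so what is attached to this nitrogen matters a great deal. The weak result for compound 2 therefore does not count against every amine on such a chain: the aminomethyl group also compares well with the (1-carbamoylethyl)amino group, with a 14-fold lower number from compound 1 to compound 3 (1.15 log units; beyond the scatter) and compound 3 the strongest inhibitor of the three. Nothing available explains why the smaller group gives so much lower a number.

As far as these compounds go, how the large step divides between the benzyl and methyl groups remains open, and a methylamino or benzylamino group here could separate the two. Also open, from the compounds shown here alone, is whether a longer chain carrying the amine, or a carboxylic acid in its place, would keep the number low.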